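Carbamoyl to methoxymethyl: working notes on the solubility series

The source may hold more compounds than are shown below. What is called first, only, known or untested is meant among the compounds shown, and "the series" means these compounds.

In a physicochemical assay for solubility, read by chemiluminescence, measured as kinetic solubility (a lower number here means a less soluble compound, a higher number a more soluble compound), compound 1 `O=S(=O)(Nc1ncnc2[nH]nc(O)c12)c1cccc(Cl)c1Cl` returns only a limit, >= 234000 nM. Compound 2 `COc1nn(C(C)C)c2ncnc(NS(=O)(=O)c3cccc(Cl)c3Cl)c12` returns a number, 404000 nM. Compound 3 `COc1nn(CC(N)=O)c2ncnc(NS(=O)(=O)c3cccc(Cl)c3Cl)c12` also returns only a limit, >= 490000 nM. Compound 3 therefore has a floor and no measured number.

Compound 4 `COCCn1nc(OC)c2c(NS(=O)(=O)c3cccc(Cl)c3Cl)ncnc21` carries methoxymethyl in place of carbamoyl on a saturated chain carbon bound to an aromatic nitrogen. Cut one bond further out, the same difference reads carbamoylmethyl to 2-methoxyethyl.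

Within the data shown here, the one measured step bearing on this change is an at least 1.2-fold higher number from compound 2 to compound 3 (0.08 log units; that floor lies within the scatter), with carbamoylmethyl in place of isopropyl on an aromatic nitrogen. Among the measured compounds shown here, that step gives a floor rather than a size, and no measured pair isolates the loss of carbamoyl. Compound 2 has no carbamoyl and still gives 404000 nM, so removing that group is not expected to move the number far. As far as these compounds go, no step beyond the scatter is expected in this assay, and direction stays open. The estimated step is an at least 1.2-fold lower number from compound 3 to compound 4 (0.08 log units; that floor lies within the scatter). Compound 4 is expected at 400000 nM, with an estimated range of 200000 nM to 600000 nM.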

Compound 4, solubility: >= 442000 nM
Compound 4: no number, only a limit (the forecaster's own chance of this, stated with the estimate: 35%); at least 1.1-fold (0.04 log units) between middle value and limit.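

In this assay compound 4 returns a limit and not a number: the limit of >= 442000 nM in this assay, at which 1 of the 4 values shown sits. Among these compounds, the step from compound 3 to compound 4 cannot be read, as both of its ends are limits, so the exchange of carbamoyl for methoxymethyl on a saturated chain carbon bound to an aromatic nitrogen has no measured size; what is new is only that a group counted with 0 hydrogen-bond donors also ends at a limit in this assay, as carbamoyl does. The one readable step, 2-methoxyethyl in place of isopropyl on an aromatic nitrogen, is an at least 1.0-fold higher number from compound 2 to compound 4 (0.03 log units; that floor lies within the scatter), and so neither step shown from compound 2 at this position goes beyond the scatter.

As far as these compounds go, whether carbamoyl and methoxymethyl differ at all here stays open, and so do the true numbers of compound 3 and compound 4, which are known only as limits. Also open, from the compounds shown here alone, is whether any group on this aromatic nitrogen gives a step beyond the scatter, for instance an amine, a carboxylic acid or a longer chain.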